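The source may hold more compounds than are shown below. What is called first, only, known or untested is meant among the compounds shown, and "the series" means these compounds.

The compounds share one core bearing a thiourea, and all are compared in a functional assay on MDA-MB-231 cells (Homo sapiens) for inhibition, read by MTT assay, with a stated time of 48 h; a higher number here means a weaker inhibitor of growth, a lower number a stronger inhibitor of growth. Compound 1 `Oc1ccc(Nc2ncnc3ccc(NC(=S)NCc4ccccc4)cc23)cc1` gives 27000 nM in this assay. For compound 2 `N=C(N)NS(=O)(=O)c1ccc(Nc2ncnc3ccc(NC(=S)NCc4ccccc4)cc23)cc1` the assay reports only a limit, > 30000 nM, that is the limit of > 30000 nM in this assay, at which 1 of the 3 values shown sits. Compound 3 `Oc1ccc(NC(=S)Nc2ccc3ncnc(Nc4cccc(Br)c4)c3c2)cc1` gives 17300 nM in this assay, the lowest of the two numbers shown; compound 1 stands nearest, and that gap lies within the scatter, so no order between the two can be read.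

Among the compounds with values here, the only step measured between compounds that differ in one place is an at least 1.1-fold higher number from compound 1 to compound 2 (0.04 log units; that floor lies within the scatter); it replaces one oxygen atom on an aromatic carbon and does not touch the thiourea nitrogen.

Compound 4 `CNC(=S)Nc1ccc2ncnc(Nc3cccc(Br)c3)c2c1` differs from compound 3 by methyl in place of 4-hydroxyphenyl on an amide-type nitrogen. Within the data shown here, no measured step bears directly on this change, and the single recorded step lies within the scatter in any case. The chemist therefore expects no movement beyond the scatter in this assay, a 1.4-fold higher number from compound 3 to compound 4 (0.16 log units; within the scatter). For compound 4 the estimated value in this assay is 25000 nM, within a range from 10000 nM to 60000 nM.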

Compound 4, concentration for 50% growth inhibition: > 30000 nM
Compound 4: no number, only a limit (the forecaster's own chance of this, stated with the estimate: 35%); middle value at least 1.2-fold (0.07 log units) away from the limit.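

In this assay, within the data shown here, the first measured change on this amide-type nitrogen of the thiourea, methyl in place of 4-hydroxyphenyl, gives an at least 1.7-fold higher number from compound 3 to compound 4 (0.23 log units; that floor lies within the scatter). The floor of this step lies within the scatter, so the result neither establishes a real loss on removing the aromatic ring with its hydroxyl nor excludes a large one, though it gives no sign that methyl improves on 4-hydroxyphenyl at this position. For compound 4 the result is a limit and not a number: the limit of > 30000 nM in this assay, at which 2 of the 4 values shown sit.

The compounds shown leave open whether any difference at this nitrogen would follow from the aromatic ring itself or from its hydroxyl, a question that an unsubstituted phenyl or a 4-methoxyphenyl group at the same place would address. They also leave open how a longer chain such as butyl, or an intermediate group such as ethyl, would read here, and whether the size of the step could be fixed at all with a compound whose value falls short of the limit.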